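The compounds below may be only part of what the source reports. "The series", "measured", "known", "first", "only" and "open" are said of these compounds alone.

Measured in an ADME assay on MT4 cells (Homo sapiens) for cytotoxicity, read by XTT assay, with a stated time of 5 days; a lower number here means that less compound is tolerated, a higher number that more compound is tolerated:
- Compound 1 `CNC(=O)[C@@H](NC(=O)[C@](O)(CCN(Cc1ccc(Br)cc1)NC(=O)[C@@H](NC(=O)OC)C(C)(C)C)Cc1ccccc1)C(C)(C)C`: > 10000 nM
- Compound 2 `CNC(=O)[C@@H](NC(=O)[C@@](O)(CCN(Cc1ccc(Br)cc1)NC(=O)[C@@H](NC(=O)OC)C(C)(C)C)Cc1ccccc1)C(C)C`: > 10000 nM

Both entries are limits of the assay and not numbers, so neither compound has a defined half-maximal cytotoxic concentration. Compound 2 stands at the limit of > 10000 nM in this assay, at which 2 of the 2 values shown sit. Going by the values given here, no comparison between the two compounds can be drawn from these limits, and no measured step shows how large a single structural change can be in this assay.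

The next compound is compound 3 `CNC(=O)[C@@H](NC(=O)[C@](O)(CCN(Cc1ccc(Br)cc1)NC(=O)[C@@H](NC(=O)OC)C(C)(C)C)Cc1ccccc1)C(C)C`, which is related to compound 2 as follows: the two compounds have the same atoms and bonds and differ only in configuration as drawn: 1 of 3 stereo elements differ; a stereocentre at a saturated chain carbon is drawn S in compound 2 and R in compound 3. Nothing enters or leaves, as the two compounds have the same atoms and bonds.

The expectation rests on compound 2, whose limit is > 10000 nM. A single change of configuration is therefore expected to cause no shift beyond the scatter in this assay. The expected change, a number no higher from compound 2 to compound 3 (the limit leaves the size open), is estimated to lie within the scatter. For compound 3 the estimated value is 10000 nM, with an expected range of 5000 nM to 20000 nM, and the assay will quite probably report only a limit again.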

Compound 3, half-maximal cytotoxic concentration: > 10000 nM
Compound 3 gave a limit, no number; the forecaster's own chance of this, stated with the estimate: 85%; the middle value lies on the limit itself.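

No step from compound 1 or compound 2 to compound 3 can be read in this assay, since all three compounds stand at one limit and none has a number: the limit of > 10000 nM in this assay, at which 3 of the 3 values shown sit.

The compounds shown leave open where the half-maximal cytotoxic concentration of each lies, and whether the change of configuration between compound 2 and compound 3 shifts it at all.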